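Acid to Amide at the Chain End of Compound 3

This account rests on a few compounds, and the source may have more. Where it says the series, first, only, none or still open, it means among the compounds named here.

Of the compounds shown here, three sharing one core have been tested in an assay on A7R5 cells for displacement of a labelled ligand from Endothelin-1 receptor (Rattus norvegicus); a lower number here means a stronger inhibitor, a higher number a weaker inhibitor. Compound 1 `CCc1onc(NS(=O)(=O)c2ccc(C(C)(C)C)cc2)c1Sc1cccc(OC)c1` gives 800 nM. Compound 2 `COc1cccc(Sc2c(NS(=O)(=O)c3ccc(C(C)(C)C)cc3)noc2C)c1` gives 530 nM in this assay, and the step is a 1.5-fold lower number from compound 1 to compound 2 (0.18 log units; within the scatter). Compound 3 `COc1cccc(Sc2c(NS(=O)(=O)c3ccc(C(C)(C)C)cc3)noc2CCCC(=O)O)c1` gives 4300 nM, the highest number of the three: against compound 1 the step is a 5.4-fold higher number from compound 1 to compound 3 (0.73 log units; beyond the scatter), and against compound 2 it is an 8.1-fold higher number from compound 2 to compound 3 (0.91 log units; beyond the scatter). Both steps show the chain ending in a carboxy group raising the number.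

Compound 4 `COc1cccc(Sc2c(NS(=O)(=O)c3ccc(C(C)(C)C)cc3)noc2CCCC(N)=O)c1` keeps that chain but changes its end: amino in place of hydroxy on a carbonyl carbon, so the carboxy becomes a carbamoyl. Among the compounds with values here, no measured pair covers this exchange; the measured steps only show what attaching the acid-bearing chain did, not what altering its end does. Within the data shown here, with no comparable step available, compound 4 is expected to stay near compound 3, the step being estimated as a 1.4-fold lower number from compound 3 to compound 4 (0.16 log units; within the scatter). The estimate for compound 4 in this assay is 3000 nM, with a range from 1000 nM to 10000 nM.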

Compound 4, half-maximal inhibitory concentration: 6300 nM
Compound 4: the middle estimate sits 2.1-fold (0.32 log units) below what was measured; the measured number falls inside the stated range.
By their numbers in this assay, from the lowest: compounds 2 and 1 (each within the scatter of the next); then compounds 3 and 4 (each within the scatter of the next).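

Exchanging carboxy for carbamoyl at the chain end gives a 1.5-fold higher number from compound 3 to compound 4 (0.17 log units; within the scatter), so this assay does not separate these two chain ends. The higher number therefore does not require the carboxy group: the chain ending in carbamoyl shows a 12-fold higher number from compound 2 to compound 4 (1.08 log units; beyond the scatter) and a 7.9-fold higher number from compound 1 to compound 4 (0.90 log units; beyond the scatter), steps that resemble those seen earlier for the chain ending in carboxy. Nothing available here offers an explanation for this shared behaviour.

As far as these compounds go, what remains open is whether the chain alone is enough to raise the number, which a plain butyl group at this position could test. How a methyl ester at the chain end, or a longer or shorter chain ending in carbamoyl, would read in this assay is also unknown.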